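The source may hold more compounds than are shown below. What is called first, only, known or untested is meant among the compounds shown, and "the series" means these compounds.

Among the measured compounds shown here, in a functional assay on HCT-15 cells (Homo sapiens) (on this read-out higher numbers stand for an effect only at larger amounts of compound and lower numbers for an effect already at smaller amounts), compound 2 `CCOC(=O)C(=O)N1N=C(c2ccc(N(C)C)cc2)OC1c1cc(OC)c(OC)c(OC)c1` gives 45 uM, the higher of the two numbers so far, and compound 1 `COc1cc(C2OC(c3ccc(N(C)C)cc3)=NN2C=O)cc(OC)c1OC` gives 0.096 uM. Compound 3 `COC(=O)N1N=C(c2ccc(N(C)C)cc2)OC1c1cc(OC)c(OC)c(OC)c1` has methoxy in place of ethoxycarbonyl on a carbonyl carbon. For the measured compounds named here, the only measured step at this carbonyl carbon, a 470-fold higher number from compound 1 to compound 2 (2.67 log units; beyond the scatter), is large and points to a strong response to the group placed there. With a single step as a guide, a moderate move towards lower numbers is expected in this assay, smaller than that step. The estimated step is a 9.0-fold lower number from compound 2 to compound 3 (0.95 log units; beyond the scatter). Compound 3 is expected at 5 uM, within 0.5 uM to 40 uM.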

Compound 3, concentration for half-maximal effect: 40 uM
The estimate for compound 3 lay 8.0-fold (0.90 log units) below the measured number, and the stated range covers the measured number.
By their numbers in this assay, from the lowest: compound 1; then compounds 3 and 2 (each within the scatter of the next).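

In this assay, methoxy in place of ethoxycarbonyl on the carbonyl carbon makes no readable difference, with a 1.1-fold lower number from compound 2 to compound 3 (0.05 log units; within the scatter). Among the compounds shown here, the large gap to compound 1 is therefore not tied to ethoxycarbonyl, since methoxy in place of hydrogen also gives a 420-fold higher number from compound 1 to compound 3 (2.62 log units; beyond the scatter), leaving hydrogen on this carbon as the only group here with a low number. No available data explain this difference. Open, going by these compounds, is whether a methyl or an amine on this carbonyl carbon would read close to compound 1 or to compound 3. Also open, on these data alone, is whether a longer chain would keep the number of compound 2.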